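The source may hold more compounds than are shown below. What is called first, only, known or untested is meant among the compounds shown, and "the series" means these compounds.

Of the compounds shown here, three sharing one core have been tested in an assay on isolated protein for inhibition of protein kinase C zeta type (Homo sapiens), read by mobility shift assay, tested at 30 uM; a lower number here means less inhibition, a higher number more inhibition at the concentration tested (going by the name of the read-out). Compound 1 `Cc1cc2[nH]nc(N)c2c(=O)[nH]1` gives 10%. Compound 2 `Nc1n[nH]c2cc(-c3ccncc3)[nH]c(=O)c12` gives 10%, level with compound 1 at the digits given and within the scatter of repeated runs, so the two together make up the bottom of the three numbers. Compound 3 `CN1CCN(c2ccc(-c3cc4[nH]nc(N)c4c(=O)[nH]3)cc2)CC1`, which carries a larger substituent on the core, gives 35%, a number beyond the scatter above compound 1. Compound 4 `CC(C)(C)c1cc2[nH]nc(N)c2c(=O)[nH]1` has not been measured yet. It differs from compound 1 in one place: tert-butyl in place of methyl on an aromatic carbon. Among the measured compounds shown here, no pair of measured compounds differs by this kind of change, so no measured step shows how much it should matter. With tert-butyl in place of methyl on the same aromatic carbon, only a small shift, if any, is expected, and for compound 4 the expected step of a number 2 percentage points higher from compound 1 to compound 4 (within the scatter) is taken to stay within the scatter. Compound 4 is therefore estimated at about 12%, in a range from 0% to 30%.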

Compound 4, a percentage reported as inhibition, at one concentration (the size of the read-out at that concentration, not a potency): -9%
Compound 4: the middle estimate sits 21 percentage points above what was measured; the whole stated range lies above it.
By their numbers in this assay, from the lowest: compound 4; then compounds 1 and 2 (each within the scatter of the next); then compound 3.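

In this assay, the aromatic carbon next to the ring nitrogen proves sensitive to the group it carries: tert-butyl in place of methyl gives a number 19 percentage points lower from compound 1 to compound 4 (beyond the scatter), a change beyond the usual scatter. Among the compounds shown here, this is the first step measured between two compounds that differ in one place, and it shows that a larger alkyl group here, bringing no ring, hydrogen-bond donor or acceptor, moves the number down rather than leaving it level. Nothing given here bears on what lies behind this drop.

Open, from the compounds shown here alone, is how an ethyl or isopropyl group, which stand between methyl and tert-butyl in carbon count, would read on this same carbon. Also open, going by these compounds, is what an amine or a carboxylic acid would do at this place on the shared core.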